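The compounds below may be only part of what the source reports. "The series", "measured", "known", "first", "only" and "open" are said of these compounds alone.

Working notes on the series. Compound 1 `CC(C)(C)N(NC(=O)c1cccc(F)c1)C(=O)c1ccccc1Cl` and compound 2 `CC(C)(C)N(NC(=O)c1cccc(C#N)c1)C(=O)c1ccccc1Cl` share the same core and differ only in the group on the second carbonyl; in an assay on cells for agonist activity at ecdysone receptor (Bombyx mori), read by a luciferase reporter, with a stated time of 24 h (on this read-out higher numbers stand for an effect only at larger amounts of compound and lower numbers for an effect already at smaller amounts), compound 1 gives 69.2 nM and compound 2 gives 955 nM. The step of a 14-fold higher number from compound 1 to compound 2 (1.14 log units; beyond the scatter) is the only one measured so far, and it places compound 2 as the higher of the two numbers, with compound 1 as its nearest neighbour at a clearly lower value.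

Compound 3 `CC(C)(C)N(NC(=O)c1ccc(Br)cc1)C(=O)c1ccccc1Cl` is not yet measured. It differs from compound 2 by 4-bromophenyl in place of 3-cyanophenyl on a carbonyl carbon. Within the data shown here, no measured step covers this exact change; the one step at hand, a 14-fold higher number from compound 1 to compound 2 (1.14 log units; beyond the scatter), shows that a cyano group in place of a halogen on that ring moved the number strongly upward. Returning to a halogen, now bromine as 4-bromophenyl, is therefore expected to move the number of compound 3 downward again, though the change of ring position leaves the size open. The expected step is a 4.8-fold lower number from compound 2 to compound 3 (0.68 log units; beyond the scatter). For compound 3 the estimate in this assay is 200 nM, with a range from 40 nM to 1000 nM.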

Compound 3, half-maximal effective concentration: 33.9 nM
Beside the measured number, compound 3's estimate is 5.9-fold (0.77 log units) above it, outside the stated range (below it).
By their numbers in this assay, from the lowest: compound 3; then compound 1; then compound 2.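

In this assay, the group on the carbonyl carbon whose other neighbour is the amide-type nitrogen now shows a second large effect, a 28-fold lower number from compound 2 to compound 3 (1.45 log units; beyond the scatter), so the high number of compound 2 is tied to 3-cyanophenyl in this comparison and not to the shared core. With a 2.0-fold lower number from compound 1 to compound 3 (0.31 log units; beyond the scatter), the two halogen-bearing rings, 3-fluorophenyl and 4-bromophenyl, lie much closer to each other than either lies to 3-cyanophenyl, although their gap is still beyond the scatter and compound 3 holds the lowest number of the three, so a low number at this position does not depend on the exact ring of compound 1. Nothing available here gives a measured reason for these differences.

Compound 1 and compound 3 differ in both the halogen and its place on the ring, and the compounds shown do not separate these two changes, so neither can be credited with the step between them. Also open, from the compounds shown here alone, is how this position responds to groups of other kinds on the ring, such as a methoxy group, an amine or a carboxylic acid, and whether the nitrile gives the same high number at the ring place held by bromine in compound 3.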